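Shifting Fluorines on the Arylidene Ring of a Thiosemicarbazone

The compounds below may be only part of what the source reports. "The series", "measured", "known", "first", "only" and "open" are said of these compounds alone.

Compound 1 `Fc1cccc(F)c1/C=N/NC(=S)Nc1cccc2ccccc12` was tested in a functional assay on A549 cells (Homo sapiens) for cytotoxicity, read by XTT assay, with a stated time of 24 h (on this read-out lower numbers stand for stronger inhibition and higher numbers for weaker inhibition), and gave 500 ug/mL. Two relatives keep the rest of the molecule and change only the difluorophenyl pattern on the carbon with a double bond to nitrogen. Compound 2 `Fc1ccc(/C=N/NC(=S)Nc2cccc3ccccc23)cc1F` gave 125 ug/mL in this assay, and compound 3 `Fc1ccc(/C=N/NC(=S)Nc2cccc3ccccc23)c(F)c1` gave 31.3 ug/mL. Among these three, compound 1 holds the highest number: the step of a 4.0-fold lower number from compound 1 to compound 2 (0.60 log units; beyond the scatter) and the step of a 16-fold lower number from compound 1 to compound 3 (1.20 log units; beyond the scatter) both go down, and between the two relatives a 4.0-fold lower number from compound 2 to compound 3 (0.60 log units; beyond the scatter) is also beyond the scatter.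

Compound 4 `Fc1ccc(F)c(/C=N/NC(=S)Nc2cccc3ccccc23)c1` has not yet been measured in this assay. It differs from compound 1 in one place (2,5-difluorophenyl in place of 2,6-difluorophenyl on a carbon with a double bond to nitrogen). Both measured steps away from the 2,6-difluorophenyl of compound 1 lowered the number, one of them by a large step to compound 3, whose 2,4-difluorophenyl shares one fluorine position with the 2,5-difluorophenyl of compound 4. A lowering beyond the scatter is therefore expected for compound 4, and the expected step is an 8.0-fold lower number from compound 1 to compound 4 (0.90 log units; beyond the scatter). The estimate for compound 4 in this assay is 62.5 ug/mL, expected to lie between 25 ug/mL and 250 ug/mL.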

Compound 4, half-maximal inhibitory concentration: 500 ug/mL
Beside the measured number, compound 4's estimate is 8.0-fold (0.90 log units) below it, outside the stated range (above it).
By their numbers in this assay, from the lowest: compound 3; then compound 2; then compounds 1 and 4 (each within the scatter of the next).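

In this assay, the 2,5-difluorophenyl group gave no change at the digits printed from compound 1 to compound 4 (within the scatter), so the earlier picture, in which both measured departures from 2,6-difluorophenyl lowered the number, does not hold for every such departure. The fluorine position shared with 2,4-difluorophenyl did not bring that group's low number with it, as the change from that group to 2,5-difluorophenyl gave a 16-fold higher number from compound 3 to compound 4 (1.20 log units; beyond the scatter), and the change from 3,4-difluorophenyl to 2,5-difluorophenyl gave a 4.0-fold higher number from compound 2 to compound 4 (0.60 log units; beyond the scatter). On the carbon with a double bond to nitrogen, the read-out therefore follows the particular arrangement of the two fluorines, and no evidence is available to explain why these arrangements differ.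

All four compounds carry two fluorines on this ring, so the compounds shown leave open how a single fluorine, a chlorine or a methoxy group would read at this place on the shared core. They also leave open whether the order seen here would persist if the thiourea sulfur of the core were replaced by oxygen, giving a urea-type linker.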